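Second fluoro on the benzyl ring of compound 3

The source may report more compounds than this note shows. Statements on the series, on what has been measured and on what is new or still open speak of the compounds shown alone.

Measured so far, in an assay on isolated protein for inhibition of serine/threonine-protein kinase PAK 4 (Homo sapiens), read by HTRF, with a stated time of 60 min; a higher number here means a weaker inhibitor, a lower number a stronger inhibitor:
compound 1, `Cc1cc(Nc2nc(NCc3ccccc3)nc3[nH]ncc23)n[nH]1`, gives 1960 nM
compound 2, `Cc1cc(Nc2nc(NCc3ccccc3Cl)nc3[nH]ncc23)n[nH]1`, gives 668 nM
compound 3, `Cc1cc(Nc2nc(NCc3ccc(F)cc3)nc3[nH]ncc23)n[nH]1`, gives 395 nM

Compound 3 carries the lowest number of the three. Its gap to compound 2 is within the scatter, so no order between these two is claimed; only compound 1 stands clearly apart, with a 5.0-fold lower number from compound 1 to compound 3 (0.70 log units; beyond the scatter).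

Compound 4, `Cc1cc(Nc2nc(NCc3ccc(F)cc3F)nc3[nH]ncc23)n[nH]1`, is not yet measured. It differs from compound 3 by fluoro in place of hydrogen on an aromatic carbon. Among the measured compounds shown here, two measured steps bear on a halogen entering this ring: a 2.9-fold lower number from compound 1 to compound 2 (0.47 log units; beyond the scatter) and a 5.0-fold lower number from compound 1 to compound 3 (0.70 log units; beyond the scatter), both modest and both downward in this assay. Neither step places a second halogen on a ring that already carries one, so there is no direct measurement of stacking two halogens. The chloro of compound 2 likewise entered an aromatic carbon ortho to a large group, and that step was the smaller of the two. A modest downward step, or none beyond the scatter, is therefore expected in this assay.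

Compound 4 is expected to give 250 nM, with a range from 100 nM to 700 nM, which amounts to an expected 1.6-fold lower number from compound 3 to compound 4 (0.20 log units; within the scatter).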

Compound 4, half-maximal inhibitory concentration: 96.1 nM
For compound 4 the middle estimate is 2.6-fold (0.42 log units) above the measured one, and the stated range ends above it.
By their numbers in this assay, from the lowest: compound 4; then compounds 3 and 2 (each within the scatter of the next); then compound 1.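

In this assay, a second halogen on a ring that already carries one still lowers the number: fluoro entering the aromatic carbon ortho to a large group and meta to a fluoro group gives a 4.1-fold lower number from compound 3 to compound 4 (0.61 log units; beyond the scatter). Among the compounds shown here, the first fluoro therefore does not exhaust what this ring can gain, and the 2,4-difluorophenyl group now stands clear of the other benzyl rings, with a 7.0-fold lower number from compound 2 to compound 4 (0.84 log units; beyond the scatter) against the 2-chlorophenyl ring and a 20-fold lower number from compound 1 to compound 4 (1.31 log units; beyond the scatter) against the plain phenyl ring, the only large step so far. No measurement at hand bears on what lies behind these steps.

As far as these compounds go, it remains open whether fluoro on the carbon ortho to a large group would give a comparable step without the second fluoro on the ring, so the share of each fluoro in the combined step cannot yet be separated. Also open, from the compounds shown here alone, is whether this carbon tolerates anything larger than fluoro alongside the 4-fluoro group, such as chloro, methoxy, trifluoromethyl or an amine.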